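Sulfonamide Substituent and Inhibition of a Urate Transporter

The source may report more compounds than this note shows. Statements on the series, on what has been measured and on what is new or still open speak of the compounds shown alone.

The measured compounds:
compound 1 `NS(=O)(=O)CSc1nnc(Br)n1Cc1ccc(Br)c2ccccc12`, 365000 nM
compound 2 `O=S(=O)(CSc1nnc(Br)n1Cc1ccc(Br)c2ccccc12)Nc1cncc(C(F)(F)F)c1`, 6380 nM
compound 3 `O=S(=O)(CSc1nnc(Br)n1Cc1ccc(Br)c2ccccc12)Nc1ccc(Cl)nc1`, 1940 nM

In an assay on HEK293 cells for inhibition of solute carrier family 22 member 12 (Homo sapiens) (on this read-out lower numbers stand for stronger inhibition and higher numbers for weaker inhibition), compound 1 gives 365000 nM, the highest of the three numbers. Replacing the hydrogen on the sulfonamide nitrogen with an aromatic group brings a large change in each measured case: a 57-fold lower number from compound 1 to compound 2 (1.76 log units; beyond the scatter) and a 190-fold lower number from compound 1 to compound 3 (2.27 log units; beyond the scatter). Between the two aryl groups the difference is smaller, a 3.3-fold lower number from compound 2 to compound 3 (0.52 log units; beyond the scatter).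

Compound 4 `O=S(=O)(CSc1nnc(Br)n1Cc1ccc(Br)c2ccccc12)Nc1cccnc1Cl` is not yet measured in this assay. It differs from compound 1 by 2-chloropyridin-3-yl in place of hydrogen on a sulfonamide nitrogen. Both measured steps that introduce a pyridinyl group on the sulfonamide nitrogen bear on it, and both were large in the same direction, so a large step toward a lower number is expected for compound 4 in this assay, roughly a 91-fold lower number from compound 1 to compound 4 (1.96 log units; beyond the scatter). Compound 4 is therefore expected to give about 4000 nM, in a range from 1000 nM to 20000 nM.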

Compound 4, half-maximal inhibitory concentration: 5100 nM
Beside the measured number, compound 4's estimate is 1.3-fold (0.11 log units) below it; low and high end bracket the measured number.
By their numbers in this assay, from the lowest: compound 3; then compounds 4 and 2 (each within the scatter of the next); then compound 1.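

In this assay, a third pyridinyl group on the sulfonamide nitrogen, 2-chloropyridin-3-yl, again brings a large change, a 72-fold lower number from compound 1 to compound 4 (1.85 log units; beyond the scatter), so the gain over the unsubstituted sulfonamide holds for all three groups shown. The new compound also shows that two isomeric chloropyridinyl groups are not equivalent: a 2.6-fold higher number from compound 3 to compound 4 (0.42 log units; beyond the scatter), a modest but real difference, while 2-chloropyridin-3-yl and 5-(trifluoromethyl)pyridin-3-yl cannot be told apart, a 1.3-fold lower number from compound 2 to compound 4 (0.10 log units; within the scatter). Nothing available explains why the isomers differ.

From the compounds shown here alone, whether a plain phenyl group or a simple methyl on the sulfonamide nitrogen would give a step of similar size remains open. So does the effect of a fluorine or a methoxy group in place of the chlorine on the pyridine ring.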